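A few compounds are considered here, and "the series" means these few. Any claim that something is new, unique, unknown or untested is made for them only; others in the source may bear on it.

Measured so far in a functional assay on ileum for inhibition of histamine H1 receptor (Cavia porcellus); a lower number here means a stronger inhibitor, a higher number a weaker inhibitor:
- compound 1, `CCOCCn1c(N2CCN(C)CC2)nc2ccccc21`: 10 nM
- compound 2, `C=CCOCCn1c(N2CCCN(C)CC2)nc2ccccc21`: 10 nM
- compound 3, `CCCCN1CCCN(c2nc3ccccc3n2CCOCC)CC1`: 8.4 nM

Three compounds, all built on the shared core with a cyclic diamine on one side and an alkoxyethyl chain on the other, and all three fall within a narrow band in this assay. Compound 1 stands level with compound 2 at the digits shown; compound 3 gives a number that differs from that of compound 1 only within the scatter, so no order among the three can be read from these values. The change of ring size between compound 1 and compound 2, and the further change of the basic nitrogen substituent in compound 3, leaves the read-out where it was.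

Compound 4, `CCCOCCn1c(N2CCN(C)CC2)nc2ccccc21`, has not yet been measured. Compared with compound 1 the difference is methyl in place of hydrogen on a saturated chain carbon, two bonds along the chain from an oxygen on a saturated carbon. For the measured compounds named here, no measured pair in the set shows this particular change, so the expectation rests on the flatness of the three numbers under other edits in the same region of the molecule. Given that flatness, the step from compound 1 to compound 4 in this assay is expected to stay within the scatter, with no direction favoured: no change at the digits printed from compound 1 to compound 4 (within the scatter). Compound 4 is therefore estimated at 10 nM, expected to lie between 4 nM and 25 nM.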

Compound 4, half-maximal inhibitory concentration: 20 nM
Estimate against measurement, compound 4: 2.0-fold (0.30 log units) below, and the stated range covers the measured number.
By their numbers in this assay, from the lowest: compounds 3, 1, 2 and 4 (each within the scatter of the next, the first and the last beyond it).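

In this assay, the change from ethoxy to propoxy gives a 2.0-fold higher number from compound 1 to compound 4 (0.30 log units; within the scatter). For the compounds shown here, this is the first step that isolates a single place, as compounds 1, 2 and 3 each differ from one another in more than one place and their shared band could not be assigned to any one edit. Methyl in place of hydrogen on this saturated chain carbon, two bonds along the chain from an oxygen on a saturated carbon, therefore leaves the read-out within the scatter, so this one step supports no order between compound 1 and compound 4, and no measurement at hand bears on why the read-out holds at this position.

Still open, going by these compounds, is how far the ether chain can be altered at this position: a longer chain such as butoxy, or a chain ending in an amine or a carboxylic acid, could show whether the read-out stays in this band or leaves it. Also open, on these data alone, is whether the same methyl gives a similar step on the diamine ring of compound 2 or compound 3, where the ring and its nitrogen substituent differ from those of compound 1.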